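Fluoro for chloro on a dithiocarbamate-linked benzamide series

A few compounds are considered here, and "the series" means these few. Any claim that something is new, unique, unknown or untested is made for them only; others in the source may bear on it.

Measured compounds:
- compound 1 `Nc1ccccc1NC(=O)c1ccc(CSC(=S)N2CCN(c3ccc(Cl)cc3)CC2)cc1`: 32.2%
- compound 2 `Nc1ccccc1NC(=O)c1ccc(CSC(=S)N2CCCc3ccccc32)cc1`: 26.5%

Two compounds share the benzamide core carrying the dithiocarbamate arm and have been tested in a functional assay on A-375 cells (Homo sapiens) for antiproliferative activity, read by CCK-8 assay, with a stated time of 72 h, tested at 2 uM; on this read-out lower numbers stand for a weaker effect and higher numbers for a stronger effect at the one concentration tested. Compound 1 `Nc1ccccc1NC(=O)c1ccc(CSC(=S)N2CCN(c3ccc(Cl)cc3)CC2)cc1` gives 32.2%, the higher of the two numbers, while compound 2 `Nc1ccccc1NC(=O)c1ccc(CSC(=S)N2CCCc3ccccc32)cc1` gives 26.5%; the gap between them lies within the usual scatter, so the two values show no separation that can be relied on. Among the measured compounds shown here, no two of the measured compounds differ in a single place, so no measured step is available.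

Compound 3 `Nc1ccccc1NC(=O)c1ccc(CSC(=S)N2CCN(c3ccc(F)cc3)CC2)cc1` differs from compound 1 in one place: fluoro in place of chloro on an aromatic carbon. For the measured compounds named here, with no measured step to lean on, a change of this kind is expected to move this assay little, if at all, beyond the scatter, and in no particular direction. The estimated step of a number 3.2 percentage points lower from compound 1 to compound 3 (within the scatter) is expected to be small. For compound 3 the expected value is 29%, in a range from 16% to 42%.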

Compound 3, a percentage reported as inhibition, at one concentration (the size of the read-out at that concentration, not a potency): 20.9%
Estimate against measurement, compound 3: 8.1 percentage points above, and the stated range covers the measured number.
By their numbers in this assay, from the lowest: compounds 3, 2 and 1 (each within the scatter of the next, the first and the last beyond it).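

In this assay, among the compounds shown here, the change from 4-chlorophenyl to 4-fluorophenyl gives a number 11.3 percentage points lower from compound 1 to compound 3 (beyond the scatter) and so supplies the first measured step between compounds that differ in one place. It shows that this aromatic carbon, para to a large group, is not indifferent to which of these two halogens it carries, although the step is only modest in size. Nothing available bears on why the number moves in this direction.

On these data alone, what a bromo, methyl, methoxy or trifluoromethyl group at the same place would do remains open, as does the effect of plain hydrogen there. Also open, as far as these compounds go, is whether the same step would appear at other concentrations, as a reading at one concentration gives no potency.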